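Chain-terminus variation on the spiro amide series

This account rests on a few compounds, and the source may have more. Where it says the series, first, only, none or still open, it means among the compounds named here.

The series shares one core carrying a glycinamide arm; the arm terminus differs. Among the measured compounds shown here, compound 3 `COC(=O)CCCNC(=O)CN1CN(c2ccccc2)C2(CCN(C(=O)c3ccc(C(C)(C)C)cc3)CC2)C1=O` ends in a methoxycarbonyl group, and in an assay on HEK293 cells for displacement of a labelled ligand from NPC1-like intracellular cholesterol transporter 1 (Homo sapiens) (a lower number here means a stronger inhibitor, a higher number a weaker inhibitor), compound 3 gives "not determined" (no result reported), so it stands nowhere on the numbers so far. Compound 4 `CC(C)(C)c1ccc(C(=O)N2CCC3(CC2)C(=O)N(CC(=O)NCCCCN)CN3c2ccccc2)cc1` differs from compound 3 by aminomethyl in place of methoxycarbonyl on a saturated chain carbon, three bonds along the chain from an amide-type nitrogen, which turns the ester-terminated chain into a 4-aminobutyl chain.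

Two measured compounds bear on this. Compound 1 `CC(C)(C)c1ccc(C(=O)N2CCC3(CC2)C(=O)N(CC(=O)NCN)CN3c2ccccc2)cc1` carries the shortest amine chain and in this assay compound 1 gives 26500 nM. Compound 2 `CC(C)(C)c1ccc(C(=O)N2CCC3(CC2)C(=O)N(CC(=O)NCCCCCNS(C)(=O)=O)CN3c2ccccc2)cc1` carries a 4-(methanesulfonamido)butyl chain, and in this assay compound 2 gives 5500 nM; the step of a 4.8-fold lower number from compound 1 to compound 2 (0.68 log units; beyond the scatter) shows that the longer, capped chain reads modestly lower. Compound 4 sits between these two designs, with the longer chain but a free amine. A number between those of compound 1 and compound 2 is therefore expected, without a measured step to fix it. The expected value for compound 4 in this assay is 11000 nM, in the range 3500 nM to 35000 nM.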

Compound 4, half-maximal inhibitory concentration: 14500 nM
Beside the measured number, compound 4's estimate is 1.3-fold (0.12 log units) below it; the range from low to high includes it.
By their numbers in this assay, from the lowest: compound 2; then compounds 4 and 1 (each within the scatter of the next).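

Capping matters more than chain length at this terminus: amino in place of (methanesulfonamido)methyl, four bonds along the chain from an amide-type nitrogen, gives a 2.6-fold higher number from compound 2 to compound 4 (0.42 log units; beyond the scatter) in this assay and lies beyond the scatter. By contrast, 3-aminopropyl in place of amino gives a 1.8-fold lower number from compound 1 to compound 4 (0.26 log units; within the scatter) and stays within the scatter, so the free-amine chains of these two compounds do not separate in this assay even though one chain is longer. No supporting measurement accounts for either step.

With no number for compound 3, the change from methoxycarbonyl to aminomethyl cannot be read. From the compounds shown here alone, it remains open whether a carboxylic acid, an acetamide cap or a longer sulfonamide-capped chain at this terminus would read lower than compound 2 in this assay on this core.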